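Isoxazolyl pyrazolopyrimidines: ring-to-chain change at the ring nitrogen

The source may hold more compounds than are shown below. What is called first, only, known or untested is meant among the compounds shown, and "the series" means these compounds.

Measured compounds:
compound 1 `CC(C)n1nc(-c2ccon2)c2c(N)ncnc21` gives 213 nM
compound 2 `CC(C)n1nc(-c2cc(C(C)(C)C)on2)c2c(N)ncnc21` gives 210 nM
compound 3 `Nc1ncnc2c1c(-c1cc(C3CC3)on1)nn2C1CCCCC1` gives 2 nM

In an assay on isolated protein for inhibition of proto-oncogene tyrosine-protein kinase receptor Ret (Homo sapiens), read by radiometric assay and 33P incorporation, in the presence of a further agent that is not named here (on this read-out lower numbers stand for stronger inhibition and higher numbers for weaker inhibition), compound 3 holds the lowest number of the three; compound 2 and compound 1 both stand far higher, beyond the scatter. Within the data shown here, compound 3 differs from compound 2 in two places, so only the two values are compared, no single step. Among the measured compounds shown here, the one measured step, a 1.0-fold lower number from compound 1 to compound 2 (0.01 log units; within the scatter), sits on an aromatic carbon of the five-membered ring and lies within the scatter.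

Compound 4 `CCCCCCCn1nc(-c2cc(C3CC3)on2)c2c(N)ncnc21` is not yet measured. It differs from compound 3 by heptyl in place of cyclohexyl on an aromatic nitrogen. For the measured compounds named here, no measured step touches the substituent on the aromatic nitrogen, so nothing here calibrates this change; the step of a 1.0-fold lower number from compound 1 to compound 2 (0.01 log units; within the scatter) concerns another position and is uninformative for it. The number for compound 4 in this assay is therefore expected to move upward from compound 3 with wide uncertainty, as a 6.0-fold higher number from compound 3 to compound 4 (0.78 log units; beyond the scatter). The estimate for compound 4 is 12 nM, with a range from 2.5 nM to 60 nM.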

Compound 4, half-maximal inhibitory concentration: 96 nM
For compound 4 the middle estimate is 8.0-fold (0.90 log units) below the measured one; measured number above the stated range.
By their numbers in this assay, from the lowest: compound 3; then compound 4; then compounds 2 and 1 (each within the scatter of the next).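

In this assay the substituent on the aromatic nitrogen now has a measured step of its own: a 48-fold higher number from compound 3 to compound 4 (1.68 log units; beyond the scatter) with heptyl in place of cyclohexyl. The change in atom count is small, yet this step is large and beyond the scatter, so the number at this position depends on more than the carbon count of the group. Among these compounds, the only earlier step, on an aromatic carbon of the five-membered ring, stayed within the scatter, which makes the aromatic nitrogen the one place so far where a single change moves the number beyond it. The data on hand offer no explanation for the size of this step.

With one ring and one chain, compound 3 and compound 4 cannot separate the loss of the ring from the length of the chain. A pentyl chain or a cyclopentyl ring on this nitrogen would help to separate them, and a terminal amine on the heptyl chain remains untested territory in what is shown.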